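This account rests on a few compounds, and the source may have more. Where it says the series, first, only, none or still open, it means among the compounds named here.

Compound 2 `O=C(NNC(=O)c1cc([N+](=O)[O-])c[nH]1)NC1CCCC1` gives 231000 nM in an ADME assay on Vero cells (Chlorocebus sabaeus) for cytotoxicity, read by MTT assay, with a stated time of 72 h; a higher number here means a weaker inhibitor, a lower number a stronger inhibitor. Among the three numbers in hand it stands second highest; compound 3 `O=C(NNC(=O)c1cc([N+](=O)[O-])c[nH]1)Nc1ccc(Cl)cc1` sits nearest with 218000 nM, and compound 1 `Cn1cc([N+](=O)[O-])cc1C(=O)NNC(=O)NCc1ccco1` furthest with 482000 nM. Within the data shown here, the only single-point step measured so far, a 1.1-fold lower number from compound 2 to compound 3 (0.03 log units; within the scatter), swaps the group on the amide-type nitrogen and leaves the aromatic nitrogen untouched.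

Compound 4 `Cn1cc([N+](=O)[O-])cc1C(=O)NNC(=O)NC1CCCC1` differs from compound 2 by methyl in place of hydrogen on an aromatic nitrogen. Among the measured compounds shown here, no measured step bears on this change. Compound 1 carries the same methyl on the aromatic nitrogen but also a different group on the amide-type nitrogen, so what separates its number from that of compound 2 cannot be assigned to either change alone. The step from compound 2 to compound 3 shows the series tolerating a swap on the amide-type nitrogen without movement beyond the scatter. With nothing pointing in either direction, the expectation for compound 4 is no step beyond the scatter, a 1.2-fold higher number from compound 2 to compound 4 (0.08 log units; within the scatter). Compound 4 is therefore estimated at 280000 nM, within a range from 140000 nM to 560000 nM.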

Compound 4, half-maximal inhibitory concentration: 271000 nM
Compound 4: middle estimate off by 1.0-fold (0.01 log units), on the high side; the measured number falls inside the stated range.
By their numbers in this assay, from the lowest: compounds 3, 2, 4 and 1 (each within the scatter of the next, the first and the last beyond it).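

Methyl in place of hydrogen on the aromatic nitrogen now has a direct reading: in this assay the change gives a 1.2-fold higher number from compound 2 to compound 4 (0.07 log units; within the scatter) and so leaves the number within the scatter at this position. With that methyl present on both compounds, cyclopentyl in place of (furan-2-yl)methyl on the amide-type nitrogen gives a 1.8-fold lower number from compound 1 to compound 4 (0.25 log units; within the scatter) and so also stays within the scatter, extending what the earlier swap showed for the unmethylated compounds. No measurement at hand offers an explanation for either reading.

The compounds shown leave open whether a longer chain such as propyl or benzyl on the aromatic nitrogen would stay within the scatter as methyl does. They also leave open how a chain ending in an amine or a carboxylic acid would read on either nitrogen.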